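The source may hold more compounds than are shown below. What is called first, only, known or untested is meant among the compounds shown, and "the series" means these compounds.

Going by the values given here, compound 2 `CCCCOC1CCN(c2nc(C(F)(F)F)ccc2CNC(=O)C(C)c2ccc(NS(C)(=O)=O)c(F)c2)CC1` stands at 3.5 nM in a functional assay on CHO-K1 cells for antagonist activity at transient receptor potential cation channel subfamily V member 1 (Homo sapiens), read by FLIPR (a higher number here means a weaker inhibitor, a lower number a stronger inhibitor), the lowest of the two numbers measured so far; compound 1 `CCCCNc1nc(C(F)(F)F)ccc1CNC(=O)C(C)c1ccc(NS(C)(=O)=O)c(F)c1` gives 9.1 nM, and the change between them produced a 2.6-fold lower number from compound 1 to compound 2 (0.41 log units; beyond the scatter). Compound 3 `CC(=O)OC1CCN(c2nc(C(F)(F)F)ccc2CNC(=O)C(C)c2ccc(NS(C)(=O)=O)c(F)c2)CC1` differs from compound 2 by acetyl in place of butyl on an oxygen on a saturated carbon, which, cut one bond further out, reads butoxy to acetoxy. Among the compounds with values here, no measured step touches this part of the molecule, since the only step known, a 2.6-fold lower number from compound 1 to compound 2 (0.41 log units; beyond the scatter), altered a different region. With nothing to guide direction, the expected step is a 1.7-fold higher number from compound 2 to compound 3 (0.23 log units; within the scatter), close to the scatter. Compound 3 is therefore estimated at 6 nM, within 2 nM to 20 nM.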

Compound 3, inhibition constant: 4 nM
Compound 3: middle estimate off by 1.5-fold (0.18 log units), on the high side; low and high end bracket the measured number.
By their numbers in this assay, from the lowest: compounds 2 and 3 (each within the scatter of the next); then compound 1.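

In this assay acetyl in place of butyl on this oxygen gives a 1.1-fold higher number from compound 2 to compound 3 (0.06 log units; within the scatter) and so leaves the number within the scatter, although acetyl carries a double bond and a hydrogen-bond acceptor that butyl lacks. With 4-acetoxypiperidin-1-yl in place of butylamino, the step is a 2.3-fold lower number from compound 1 to compound 3 (0.36 log units; beyond the scatter) and stays beyond the scatter, as it does for the butoxy group of compound 2. Nothing measured here explains why butoxy and acetoxy match. Going by these compounds, whether a benzoyl group or a longer chain on this oxygen, or an amine in place of the oxygen, would hold the number stays open.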